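The source may report more compounds than this note shows. Statements on the series, on what has been measured and on what is new or still open speak of the compounds shown alone.

Working notes on the series in an ADME assay on HEp-2 cells (Homo sapiens) for cytotoxicity; on this read-out lower numbers stand for higher toxicity in this test and higher numbers for lower toxicity in this test. Going by the values given here, compound 1 `CC(C)CCn1c(Cn2c(=O)n(C(C)C)c3ccccc32)nc2c(CO)cccc21` gives 22000 nM, and compound 2 `COCc1cccc2c1nc(Cn1c(=O)n(C(C)C)c3ccccc31)n2CCC(C)C` gives 26700 nM, so compound 2 stands level with compound 1, the only other measured compound. Compound 3 `COC(=O)c1cccc2c1nc(Cn1c(=O)n(C(C)C)c3ccccc31)n2CCC(C)C` differs from compound 2 by methoxycarbonyl in place of methoxymethyl on an aromatic carbon. Among the compounds with values here, the one measured step bearing on this change is a 1.2-fold higher number from compound 1 to compound 2 (0.08 log units; within the scatter), which swaps methyl for hydrogen on an oxygen on a saturated carbon and stays within the scatter. Within the data shown here, no measured step covers methoxycarbonyl itself, so this evidence is indirect. No step beyond the scatter is therefore expected in this assay, in either direction. The estimated change is a 1.1-fold lower number from compound 2 to compound 3 (0.03 log units; within the scatter). For compound 3 the expected value is 25000 nM, with an estimated range of 11000 nM to 55000 nM.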

Compound 3, half-maximal cytotoxic concentration: 49200 nM
For compound 3 the middle estimate is 2.0-fold (0.29 log units) below the measured one; low and high end bracket the measured number.
By their numbers in this assay, from the lowest: compounds 1, 2 and 3 (each within the scatter of the next, the first and the last beyond it).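

Going by these compounds alone, at this aromatic carbon, methoxycarbonyl brings the first carbonyl on the group at this position, and in this assay its exchange for methoxymethyl gives a 1.8-fold higher number from compound 2 to compound 3 (0.27 log units; within the scatter) and so leaves the two compounds level. Against hydroxymethyl at the same carbon, the change gives a 2.2-fold higher number from compound 1 to compound 3 (0.35 log units; beyond the scatter) as the first step in the series to clear the scatter, though only modestly. (Nothing measured accounts for this step).

As far as these compounds go, whether an amine, a carboxylic acid or a longer chain on this aromatic carbon would keep the numbers in the same range remains open. Also open, from the compounds shown here alone, is whether methoxycarbonyl in place of hydroxymethyl would give a step of similar size with a different group on the rest of the shared core.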